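The source may hold more compounds than are shown below. What is called first, only, known or untested is meant among the compounds shown, and "the series" means these compounds.

Measured compounds:
compound 1 `CN(CCCC(=O)NCC1=CCc2ccccc2C(CC(=O)O)C1)c1ccccn1` with 2030 nM
compound 2 `O=C(O)CC1CC(CNC(=O)CCCNc2nc3ccccc3[nH]2)=CCc2ccccc21` with 1.8 nM
compound 3 `O=C(O)CC1CC(CNC(=O)CCCNc2ccccn2)=CCc2ccccc21` with 2 nM

In a functional assay on IGROV-1 cells (Homo sapiens) for inhibition (a higher number here means a weaker inhibitor, a lower number a stronger inhibitor), compound 3 has the second highest of the three numbers. Its nearest neighbour is compound 2, and a 1.1-fold higher number from compound 2 to compound 3 (0.05 log units; within the scatter), so the two cannot be ordered. Its furthest neighbour is compound 1, where a 1000-fold lower number from compound 1 to compound 3 (3.01 log units; beyond the scatter). The two large steps, a 1100-fold lower number from compound 1 to compound 2 (3.05 log units; beyond the scatter) and a 1000-fold lower number from compound 1 to compound 3 (3.01 log units; beyond the scatter), both remove the methyl from the amine nitrogen, and what remains on that nitrogen, a 1H-benzimidazol-2-yl or a pyridin-2-yl, makes no visible difference in this assay.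

Compound 4 `O=C(O)CC1CC(CNC(=O)CCCNC2=NCCN2)=CCc2ccccc21` keeps the shared core and the unsubstituted amine nitrogen and changes only the group on that nitrogen: a group of 5 heavy atoms (3 carbon, 2 nitrogen; one five-membered non-aromatic ring with 2 hetero atoms) in place of a group of 6 heavy atoms (5 carbon, 1 nitrogen; one six-membered aromatic ring with 1 hetero atom), on an amine nitrogen. Within the data shown here, the one step that bears on this place is that from compound 2 to compound 3, which lay within the scatter. Among the measured compounds shown here, no measured step shows the entering group, so the expectation for compound 4 rests on that single comparison. The estimated step is a 1.3-fold higher number from compound 3 to compound 4 (0.10 log units; within the scatter), that is, no change beyond the scatter is expected. Compound 4 is therefore estimated at 2.5 nM in this assay, with a range from 0.8 nM to 8 nM.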

Compound 4, half-maximal inhibitory concentration: 18 nM
For compound 4 the middle estimate is 7.2-fold (0.86 log units) below the measured one, outside the stated range (above it).
By their numbers in this assay, from the lowest: compounds 2 and 3 (each within the scatter of the next); then compound 4; then compound 1.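

Among the groups on this amine nitrogen, the earlier pair gave no difference, but in this assay the five-membered non-aromatic ring separates itself from both aromatic groups, with a 9.0-fold higher number from compound 3 to compound 4 (0.95 log units; beyond the scatter) and with a 10-fold higher number from compound 2 to compound 4 (1.00 log units; beyond the scatter) as well. The position therefore does respond to the group it carries, and the two aromatic groups agree with each other while the one non-aromatic ring stands apart, a pattern that rests on these three groups alone. The shift is still much smaller than the one tied to the methylated amine, for a 110-fold lower number from compound 1 to compound 4 (2.05 log units; beyond the scatter) remains a large step, although no measurement shown here accounts for the loss on this nitrogen.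

The compounds leave open whether the step follows the loss of aromaticity or the smaller ring, and a six-membered non-aromatic group such as a tetrahydropyrimidin-2-yl or a five-membered aromatic group such as an imidazol-2-yl would separate the two. Also open, as far as these compounds go, is how a methyl on the nitrogen would read with the 1H-benzimidazol-2-yl or with the five-membered non-aromatic ring in place of the pyridin-2-yl.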